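The compounds below may be only part of what the source reports. "The series", "measured", "known", "first", "only" and "open" are said of these compounds alone.

Measured so far:
compound 1 `COc1ccc2c(c1)c(-c1cc(C(F)(F)F)c(C#N)c(-c3cn(S(=O)(=O)c4ccc(C)cc4)c4ccc(OC)cc34)n1)cn2S(=O)(=O)c1ccc(C)cc1` — 25%
compound 2 `COc1ccc2c(-c3cc(C(F)(F)F)c(C#N)c(-c4cn(S(=O)(=O)c5ccc(C)cc5)c5cc(OC)ccc45)n3)cn(S(=O)(=O)c3ccc(C)cc3)c2c1` — 33%
compound 3 `COc1ccc2c(c1)c(-c1cc(C(F)(F)F)cc(-c3cn(S(=O)(=O)c4ccc(C)cc4)c4ccc(OC)cc34)n1)cn2S(=O)(=O)c1ccc(C)cc1` — 16.7%

All three were tested in a functional assay on A549 cells (Homo sapiens) for inhibition, tested at 0.1 uM; a higher number here means a stronger effect of the compound at the concentration tested, a lower number a weaker effect. Compound 1 and compound 2 are built from the same atoms joined differently; the difference between the two cores is not broken down here. Compound 3 is compound 1 with hydrogen in place of cyano on an aromatic carbon, and that change made the step of a number 8.3 percentage points lower from compound 1 to compound 3 (within the scatter). Compound 1 and compound 2 lie within the scatter of each other, whereas compound 3 lies beyond the scatter below compound 2.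

Compound 4 `COc1ccc2c(-c3cc(C(F)(F)F)cc(-c4cn(S(=O)(=O)c5ccc(C)cc5)c5cc(OC)ccc45)n3)cn(S(=O)(=O)c3ccc(C)cc3)c2c1` has not yet been measured. It stands to compound 2 as compound 3 stands to compound 1: hydrogen in place of cyano on an aromatic carbon, the same change in the same place. Compound 4 is expected to move by a number 8 percentage points lower from compound 2 to compound 4 (within the scatter) because the earlier step of a number 8.3 percentage points lower from compound 1 to compound 3 (within the scatter) stayed within the scatter. Compound 4 is therefore estimated at 25%, between 12% and 38% in this assay.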

Compound 4, a percentage reported as inhibition, at one concentration (the size of the read-out at that concentration, not a potency): 1.7%
Beside the measured number, compound 4's estimate is 23.3 percentage points above it; measured number outside the range, below it.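

On the core of compound 2, hydrogen in place of cyano gave a number 31.3 percentage points lower from compound 2 to compound 4 (beyond the scatter). In this assay, going by these compounds alone, the size of this change depended on the core that carried it: the same change on two cores in this assay, a number 8.3 percentage points lower (within the scatter) from compound 1 to compound 3 and a number 31.3 percentage points lower (beyond the scatter) from compound 2 to compound 4, 23 percentage points apart, beyond the scatter of two such steps The step seen on one core therefore could not be carried over to the other, but this rests on only two pairs of compounds at one concentration and does not show why the two cores differ.

The compounds shown leave open whether another group on the same aromatic carbon, such as an amine or a carboxylic acid, would also behave differently on the two cores. They also leave open whether the gap would persist with a methyl group in place of the trifluoromethyl group.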